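A few compounds are considered here, and "the series" means these few. Any claim that something is new, unique, unknown or untested is made for them only; others in the source may bear on it.

Compound 1 `COc1cc2c(Oc3ccc(NC(=O)c4nnn(-c5ccc(F)cc5)c4C(F)(F)F)cc3F)ccnc2cc1OCCCN1CCCC1` gives 120 nM in a functional assay on HT-29 cells (Homo sapiens) for cytotoxicity, read by MTT assay, with a stated time of 72 h; on this read-out lower numbers stand for stronger inhibition and higher numbers for weaker inhibition. Compound 2 `COc1cc2c(Oc3ccc(NC(=O)c4nnn(-c5ccc(C)cc5)c4C(F)(F)F)cc3F)ccnc2cc1OCCCN1CCCC1` gives 550 nM in this assay. Compound 3 `COc1cc2c(Oc3ccc(NC(=O)c4nnn(-c5ccc(F)cc5)c4C(F)(F)F)cc3F)ccnc2cc1OCCCN1CCC(C)CC1` gives 160 nM in this assay, the second highest of the three numbers, nearest to compound 1 and furthest from compound 2. Compound 4 `COc1cc2c(Oc3ccc(NC(=O)c4nnn(-c5ccc(C)cc5)c4C(F)(F)F)cc3F)ccnc2cc1OCCCN1CCC(C)CC1` has not been measured yet. It differs from compound 3 by methyl in place of fluoro on an aromatic carbon. The same exchange has already been seen once, where it brought a 4.6-fold higher number from compound 1 to compound 2 (0.66 log units; beyond the scatter); the other known step, 4-methylpiperidin-1-yl in place of pyrrolidin-1-yl, brought only a 1.3-fold higher number from compound 1 to compound 3 (0.12 log units; within the scatter). A rise of about that first size is therefore expected, a 4.6-fold higher number from compound 3 to compound 4 (0.67 log units; beyond the scatter). Compound 4 is accordingly estimated at 740 nM, with a likely range from 300 nM to 1800 nM.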

Compound 4, half-maximal inhibitory concentration: 1200 nM
Beside the measured number, compound 4's estimate is 1.6-fold (0.21 log units) below it, within the range that was stated.
By their numbers in this assay, from the lowest: compounds 1 and 3 (each within the scatter of the next); then compound 2; then compound 4.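

Replacing the 4-fluorophenyl with 4-methylphenyl raises the number again when the chain ends in 4-methylpiperidin-1-yl, with a 7.5-fold higher number from compound 3 to compound 4 (0.88 log units; beyond the scatter), so the loss is not confined to the pyrrolidin-1-yl compounds, and the two cases agree: the same change on two cores in this assay, a 4.6-fold higher number (0.66 log units; beyond the scatter) from compound 1 to compound 2 and a 7.5-fold higher number (0.88 log units; beyond the scatter) from compound 3 to compound 4, 1.6-fold (0.21 log units) apart, within the scatter of two such steps. The amine exchange, which stayed within the scatter between the fluoro compounds, now gives a 2.2-fold higher number from compound 2 to compound 4 (0.34 log units; beyond the scatter), yet the two readings of it cannot be told apart: the same change on two cores in this assay, a 1.3-fold higher number (0.12 log units; within the scatter) from compound 1 to compound 3 and a 2.2-fold higher number (0.34 log units; beyond the scatter) from compound 2 to compound 4, 1.6-fold (0.21 log units) apart, within the scatter of two such steps.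

Open, going by these compounds, is how a chloro or methoxy group, or plain hydrogen, would compare with fluoro and methyl here. Also open, on these data alone, is whether the same gap holds with a morpholine at the chain end.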